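Dropping one methoxy from a weakly cytotoxic chalcone

The source may hold more compounds than are shown below. What is called first, only, known or untested is meant among the compounds shown, and "the series" means these compounds.

Of the compounds shown here, two have been measured so far. Compound 1 `COc1cc(-c2cc(/C=C/C(=O)c3ccc(N)cc3)[nH]n2)cc(OC)c1OC` gives 82% in a functional assay on HT-29 cells (Homo sapiens) for cytotoxicity, read by sulforhodamine B assay, with a stated time of 48 h, tested at 1 uM; a lower number here means a stronger effect, a higher number a weaker effect of the compound at the concentration tested. Compound 2 `COc1ccc(C(=O)/C=C/c2cc(-c3cc(OC)c(OC)c(OC)c3)n[nH]2)cc1OC` gives 88% in this assay, which is the higher of the two numbers; the step of a number 6 percentage points higher from compound 1 to compound 2 (within the scatter) is within the scatter, so the two compounds cannot be told apart on this read-out, and both leave most of the cells unaffected at the concentration tested.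

Compound 3 `COc1ccc(C(=O)/C=C/c2cc(-c3cc(OC)c(OC)c(OC)c3)n[nH]2)cc1` has not yet been measured. It differs from compound 2 in a single place: hydrogen in place of methoxy on an aromatic carbon. Within the data shown here, the one measured step, from compound 1 to compound 2, changes a different group and is within the scatter, so no measured step bears directly on the loss of a methoxy. Among the measured compounds shown here, with no relevant step to lean on, the expectation for this assay is a step from compound 2 to compound 3 of no clear size beyond the scatter, in either direction; the estimated step is a number 3 percentage points lower from compound 2 to compound 3 (within the scatter).

Compound 3 is therefore expected to give about 85% in this assay, within a range from 68% to 100%.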

Compound 3, a percentage reported as activity, at one concentration (the size of the read-out at that concentration, not a potency): 95%
Estimate against measurement, compound 3: 10 percentage points below; the range from low to high includes it.
By their numbers in this assay, from the lowest: compounds 1, 2 and 3 (each within the scatter of the next, the first and the last beyond it).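

In this assay, the methoxy that separates the 3,4-dimethoxyphenyl of compound 2 from the 4-methoxyphenyl of compound 3 makes no readable difference, with a number 7 percentage points higher from compound 2 to compound 3 (within the scatter), so this ring tolerates the change at this concentration without any clear shift in the read-out. The first gap beyond the scatter in this small set appears with methoxy in place of amino on the aromatic carbon, a number 13 percentage points higher from compound 1 to compound 3 (beyond the scatter), a modest step that gives compound 1 the stronger effect of that pair, though both compounds still leave most cells unaffected. Nothing available here explains why the amino and methoxy compounds separate in this way.

On these data alone, whether the gap belongs to the amino group itself remains open, since a hydroxyl, a dimethylamino group or a carboxylic acid in that place could test how far the number follows the group. A longer chain such as ethoxy would show whether this ring accepts more bulk, and a single concentration leaves open how these compounds would compare across a range of doses.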